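Swapping the Sulfonamide Heterocycle on the Way to Compound 3

This account rests on a few compounds, and the source may have more. Where it says the series, first, only, none or still open, it means among the compounds named here.

Compound 1 `C=C1CC[C@@H]2[C@](C)(COC(C)=O)[C@H](OC(C)=O)CC[C@@]2(C)[C@H]1CC(Nc1ccc(S(=O)(=O)Nc2nccs2)cc1)C1=CCOC1=O`: 27500 nM
Compound 2 `C=C1CC[C@@H]2[C@](C)(COC(C)=O)[C@H](OC(C)=O)CC[C@@]2(C)[C@H]1CC(Nc1ccc(S(=O)(=O)Nc2ncccn2)cc1)C1=CCOC1=O`: 6440 nM

In a functional assay on HOP-62 cells (Homo sapiens) for inhibition, read by sulforhodamine B assay, with a stated time of 48 h (on this read-out lower numbers stand for stronger inhibition of growth and higher numbers for weaker inhibition of growth), compound 2 gives the lowest of the two numbers measured; its nearest neighbour, compound 1, sits at a 4.3-fold lower number from compound 1 to compound 2 (0.63 log units; beyond the scatter), a modest step beyond the scatter. Compound 3 `C=C1CC[C@@H]2[C@](C)(COC(C)=O)[C@H](OC(C)=O)CC[C@@]2(C)[C@H]1CC(Nc1ccc(S(=O)(=O)Nc2cc(C)on2)cc1)C1=CCOC1=O` differs from compound 2 in one place: 5-methyl-1,2-oxazol-3-yl in place of pyrimidin-2-yl on a sulfonamide nitrogen. Among the compounds with values here, only one measured step bears on this change, the exchange of one heterocycle on the sulfonamide nitrogen that runs from compound 1 to compound 2, and it was modest in size. The entering group is, like the group of compound 1, a five-membered aromatic ring with two hetero atoms, so the account expects compound 3 to move back toward compound 1, with a step of a 1.9-fold higher number from compound 2 to compound 3 (0.27 log units; within the scatter) in this assay. Compound 3 is therefore estimated at 12000 nM, within 4000 nM to 35000 nM.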

Compound 3, concentration for total growth inhibition: 22900 nM
Beside the measured number, compound 3's estimate is 1.9-fold (0.28 log units) below it, within the range that was stated.
By their numbers in this assay, from the lowest: compound 2; then compounds 3 and 1 (each within the scatter of the next).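

On the sulfonamide nitrogen, the step of a 3.6-fold higher number from compound 2 to compound 3 (0.55 log units; beyond the scatter) in this assay shows that this position responds to the ring even when the counts of heavy atoms, hydrogen-bond donors and hydrogen-bond acceptors stay the same and neither group carries a net charge. The step of a 1.2-fold lower number from compound 1 to compound 3 (0.08 log units; within the scatter) shows that two different five-membered aromatic rings give numbers within the scatter of each other, so among these three compounds only the pyrimidin-2-yl compound stands apart, and none goes against that grouping. Nothing available explains why the pyrimidin-2-yl group stands apart.

With a single six-membered ring among the compounds shown, ring size cannot be separated from the identity of the ring atoms. As far as these compounds go, it also remains open whether a pyridin-2-yl or a phenyl ring on this nitrogen would group with compound 2, and what the methyl of the 5-methyl-1,2-oxazol-3-yl group contributes.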